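The source may report more compounds than this note shows. Statements on the series, on what has been measured and on what is new or still open speak of the compounds shown alone.

Within the data shown here, in an ADME assay on Raji cells (Homo sapiens) for cytotoxicity, read by CellTiter-Glo and resazurin assay, with a stated time of 72 h (on this read-out lower numbers stand for an effect already at smaller amounts and higher numbers for an effect only at larger amounts of compound), both compounds tested so far reached only a limit of the assay rather than a number. Compound 1 `COc1cccc(-c2ccc(C(=O)N(Cc3cccc(OCCCCCC(=O)O)c3)C(C)C)cc2)c1` gave the limit > 20900 nM in this assay. Compound 2 `CCOC(=O)CCCCCOc1cccc(CN(C(=O)c2ccc(-c3ccc4ccccc4c3)cc2)C(C)C)c1` gave the limit > 26000 nM in this assay. So compound 2 stands where compound 1 stands: at a limit, with no measured number for either, the two limits being the limit of > 20900 nM in this assay, at which 1 of the 2 values shown sits, and (the limit of > 26000 nM in this assay, at which 1 of the 2 values shown sits).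

Compound 3 `CCOC(=O)CCCCCOc1cccc(CN(C(=O)c2ccc(-c3cc(OC)ccc3F)cc2)C(C)C)c1` differs from compound 2 in one place: 2-fluoro-5-methoxyphenyl in place of naphthalen-2-yl on an aromatic carbon. Among the measured compounds shown here, no pair of measured compounds shows how a change of this kind moves the read-out in this assay, so there is no measured step to lean on. Given that compound 2 ends at a limit, the step expected is a step that the limit leaves unreadable from compound 2 to compound 3, that is, none beyond the usual scatter, and most likely compound 3 will again end at a limit rather than at a number. As a working figure, compound 3 is estimated at 30000 nM in this assay, with a range from 15000 nM to 80000 nM.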

Compound 3, half-maximal effective concentration: > 26000 nM
Compound 3 ended at the assay's limit; the forecaster's own chance of this, stated with the estimate: 85%; the middle value is on the limit's open side.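

Compound 2 and compound 3 both end at a limit of this assay rather than at a number, so swapping naphthalen-2-yl for 2-fluoro-5-methoxyphenyl gives no step that can be read: the limit of > 26000 nM in this assay, at which 2 of the 3 values shown sit.

The compounds shown leave open whether any of them would give a real number in this assay, and whether this swap changes the read-out at all.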